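The source may report more compounds than this note shows. Statements on the series, on what has been measured and on what is new or still open speak of the compounds shown alone.

Three related compounds have been tested in a functional assay on L929 cells (Mus musculus) for inhibition, read by MTT assay, with a stated time of 5 days; on this read-out lower numbers stand for stronger inhibition and higher numbers for weaker inhibition. Compound 1 has the structure `COc1ccc(N(Cc2ccccc2)CC(C)C)cc1` and in this assay compound 1 gives 10 ug/mL. Compound 3, with the structure `COc1ccc(NCc2ccccc2)cc1`, differs from compound 1 in a single place: hydrogen in place of isobutyl on a nitrogen on an aromatic ring. In this assay compound 3 gives 30 ug/mL, which means a 3.0-fold higher number from compound 1 to compound 3 (0.48 log units; beyond the scatter). Compound 2 has the structure `CCCCCCCCCN(CC(C)C)c1ccc(OC)cc1`; the difference between its core and the core of compound 1 is not broken down here. In this assay compound 2 gives 20 ug/mL, a number that lies within the scatter of both compound 1 and compound 3, so no order between compound 2 and either of them can be read from these values.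

Compound 4, with the structure `CCCCCCCCCNc1ccc(OC)cc1`, has not yet been measured. It arises from compound 2 by the same change that leads from compound 1 to compound 3: hydrogen in place of isobutyl on a nitrogen on an aromatic ring. The surroundings of that nitrogen are described in the same words in both cases, so the change is the same and not merely the same kind. The step expected here is a 3.0-fold higher number from compound 2 to compound 4 (0.48 log units; beyond the scatter), resting on compound 1, where this change gave a 3.0-fold higher number from compound 1 to compound 3 (0.48 log units; beyond the scatter). Among the measured compounds shown here, with only one measured instance of the change, the expectation carries considerable uncertainty. Compound 4 is therefore estimated at 60 ug/mL in this assay, with a plausible range from 30 ug/mL to 120 ug/mL.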

Compound 4, half-maximal inhibitory concentration: 12 ug/mL
For compound 4 the middle estimate is 5.0-fold (0.70 log units) above the measured one; measured number outside the range, below it.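

In this assay, hydrogen in place of isobutyl on the nitrogen does not behave alike on the two cores: the same change on two cores in this assay, a 3.0-fold higher number (0.48 log units; beyond the scatter) from compound 1 to compound 3 and a 1.7-fold lower number (0.22 log units; within the scatter) from compound 2 to compound 4, 5.0-fold (0.70 log units) apart, beyond the scatter of two such steps. Read alone, the new step is a 1.7-fold lower number from compound 2 to compound 4 (0.22 log units; within the scatter) and so shows no measurable effect of the swap on the core of compound 2, whereas the same swap on the core of compound 1 gave a 3.0-fold higher number from compound 1 to compound 3 (0.48 log units; beyond the scatter). Among the compounds shown here, this shows that the step measured on one core could not be carried over as a forecast for the other core, but with only two cores it does not show why they part ways, nor what the same swap would do on a third core.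

The compounds shown leave open what happens on the nitrogen when the isobutyl gives way to something other than hydrogen, such as an ethyl group, an acetyl group or a chain ending in a carboxylic acid. They also leave open whether a further pair of compounds, differing in this one place on a new core, would follow compound 1 and compound 3 or compound 2 and compound 4, or neither.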